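The source may report more compounds than this note shows. Statements on the series, on what has been measured and on what is new or still open speak of the compounds shown alone.

Compound 1 `COc1cc(OC)c(/C=C/S(=O)(=O)Cc2ccc(Cl)cc2)c(OC)c1` gives 7500 nM in a functional assay on DU-145 cells (Homo sapiens) for antiproliferative activity, read by trypan blue exclusion; a higher number here means a weaker inhibitor, a lower number a stronger inhibitor. Compound 2 `COc1ccc(CS(=O)(=O)/C=C/c2ccc([N+](=O)[O-])cc2)cc1` gives 7500 nM in this assay; compound 1 stands level with compound 2 on these numbers, within the scatter. Compound 3 `COc1ccc(CS(=O)(=O)/C=C/c2c(C)cccc2C)cc1` returns only a limit in this assay, > 20000 nM, which is the limit of > 20000 nM in this assay, at which 1 of the 3 values shown sits. Among the compounds with values here, no two measured compounds differ in a single place, so no measured step size is available to guide the next change. Compound 4 `COc1cc(OC)c(/C=C/S(=O)(=O)Cc2ccc(OC(F)(F)F)cc2)c(OC)c1` differs from compound 1 by trifluoromethoxy in place of chloro on an aromatic carbon. Both the leaving and the entering group lack a ring and carry no charge, so in this assay the step from compound 1 to compound 4 is expected to be small, none beyond the scatter, direction uncertain. The expected value for compound 4 is 8000 nM, with a range from 3500 nM to 20000 nM. The expected step is a 1.1-fold higher number from compound 1 to compound 4 (0.03 log units; within the scatter).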

Compound 4, half-maximal inhibitory concentration: 4000 nM
Estimate against measurement, compound 4: 2.0-fold (0.30 log units) above, and the stated range covers the measured number.
By their numbers in this assay, from the lowest: compounds 4, 1 and 2 (each within the scatter of the next). At a limit, above all of these: compound 3.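

Trifluoromethoxy in place of chloro on an aromatic carbon, para to a large group, gives a 1.9-fold lower number from compound 1 to compound 4 (0.27 log units; within the scatter) in this assay, the only single-place step among the compounds shown. This position therefore takes the larger group, 5 heavy atoms against 1, with no change beyond the scatter. Nothing measured here gives a cause for this step.

On these data alone, whether an amine or a carboxylic acid on this carbon would move the value beyond the scatter stays open. So does the effect of any single change elsewhere on the core of compound 1.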